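Trimming a benzyl to ethyl on the pyrazole core

This account rests on a few compounds, and the source may have more. Where it says the series, first, only, none or still open, it means among the compounds named here.

Compound 1 `O=C(NO)c1ccc(Cn2nc(Cc3ccccc3)cc2-c2ccc(F)cc2)cc1` gives 420 nM in an assay on cells for inhibition of protein deacetylase HDAC6 (Homo sapiens), read by fluorescence, with stated times of 15 min and 60 min (on this read-out higher numbers stand for weaker inhibition and lower numbers for stronger inhibition), the higher of the two numbers recorded; compound 2 `CCc1cc(-c2ccc(F)cc2)nn1Cc1ccc(C(=O)NO)cc1` gives 35 nM, a gap well beyond the scatter. Compound 3 `CCc1cc(-c2ccc(F)cc2)n(Cc2ccc(C(=O)NO)cc2)n1` differs from compound 1 by methyl in place of phenyl on a saturated chain carbon bound to an aromatic carbon, so the benzyl becomes an ethyl. Within the data shown here, no measured pair shows this change, so the size of the step is unknown; a modest move toward a lower number is expected, a 1.7-fold lower number from compound 1 to compound 3 (0.23 log units; within the scatter), though staying within the scatter is possible. Compound 3 is estimated at 250 nM, between 70 nM and 900 nM.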

Compound 3, half-maximal inhibitory concentration: 69 nM
Compound 3: the middle estimate sits 3.6-fold (0.56 log units) above what was measured, outside the stated range (below it).
By their numbers in this assay, from the lowest: compounds 2 and 3 (each within the scatter of the next); then compound 1.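

Cutting the benzyl back to ethyl gives a 6.1-fold lower number from compound 1 to compound 3 (0.78 log units; beyond the scatter) in this assay, so the phenyl at this saturated chain carbon is not needed for the lower number, and removing it moves the value well past the scatter. Among these compounds, this single step is the first direct reading of this position. No measurement available here explains the size of the step. The compounds shown leave open how a longer chain such as propyl, a cyclopropyl ring or an amine would read at this place.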